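Trading Cyclohexyl for Hydrogen in a Microsomal Stability Series

The source may report more compounds than this note shows. Statements on the series, on what has been measured and on what is new or still open speak of the compounds shown alone.

Among the compounds with values here, in an ADME assay on microsomes from liver (Mus musculus) for metabolic stability, read by LC-MS, with a stated time of 10 min (on this read-out lower numbers stand for a less stable compound and higher numbers for a more stable compound), compound 2 `c1cnc2c(c1)CCC[C@@H]2N(CC1CCCCC1)C[C@H]1Cc2c(cccc2N2CCNCC2)CN1` gives 85.6%, the higher of the two numbers so far. Compound 1 `CN(C[C@H]1Cc2c(cccc2N2CCNC(C)(C)C2)CN1)[C@H]1CCCc2cccnc21` gives 44%. The gap between these two compounds lies beyond the scatter. Compound 3 `CN(C[C@H]1Cc2c(cccc2N2CCNCC2)CN1)[C@H]1CCCc2cccnc21` departs from compound 2 by hydrogen in place of cyclohexyl on a saturated chain carbon bound to an amine nitrogen, or cyclohexylmethyl to methyl. Compound 1 also carries that methyl and gives 44%, so a fall beyond the scatter is expected in this assay. The expected change is a number 25.6 percentage points lower from compound 2 to compound 3 (beyond the scatter). For compound 3 the estimated value is 60%, with an expected range of 40% to 82%.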

Compound 3, percent of the compound remaining: 19.9%
The estimate for compound 3 lay 40.1 percentage points above the measured number; the measured number lies below the stated range.
By their numbers in this assay, from the lowest: compound 3; then compound 1; then compound 2.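

In this assay, hydrogen in place of cyclohexyl on a saturated chain carbon bound to an amine nitrogen gives a number 65.7 percentage points lower from compound 2 to compound 3 (beyond the scatter), so the read-out responds strongly to this position. Piperazin-1-yl in place of 3,3-dimethylpiperazin-1-yl on an aromatic carbon gives a number 24.1 percentage points lower from compound 1 to compound 3 (beyond the scatter), showing that the two methyl groups also count when the chain ends in methyl. Nothing available explains either step. As far as these compounds go, whether phenyl or cyclopropyl in place of cyclohexyl would hold the number stays open. So does the outcome of combining cyclohexylmethyl with 3,3-dimethylpiperazin-1-yl.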